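The source may hold more compounds than are shown below. What is called first, only, known or untested is meant among the compounds shown, and "the series" means these compounds.

Measured in a functional assay (Homo sapiens) for inhibition, with a stated time of 72 h; on this read-out higher numbers stand for weaker inhibition and lower numbers for stronger inhibition:
- compound 1 `COc1cc(C(=O)c2cccc3[nH]ccc23)cc(OC)c1OC`: 51.4 nM
- compound 2 `COc1cc(C(=O)c2cccc3c2ccn3C)cc(OC)c1OC`: 26.1 nM
- compound 3 `CCCn1ccc2cc(C(=O)c3cc(OC)c(OC)c(OC)c3)ccc21`: 2100 nM

Among these three, compound 3 has the highest number, well beyond the scatter from both others. Compound 4 `COc1cc(C(=O)c2ccc3c(ccn3CCC(=O)O)c2)cc(OC)c1OC` differs from compound 3 in one change: carboxy in place of methyl on a saturated chain carbon, two bonds along the chain from an aromatic nitrogen, which turns propyl into 2-carboxyethyl. Within the data shown here, the only measured step, a 2.0-fold lower number from compound 1 to compound 2 (0.29 log units; within the scatter), concerns methyl in place of hydrogen on an aromatic nitrogen and does not involve a carboxy. Among the measured compounds shown here, no measured compound carries that group, so the data give no size for this change, and only a moderate shift towards weaker inhibition in this assay is tentatively expected. The expected change is a 2.4-fold higher number from compound 3 to compound 4 (0.38 log units; beyond the scatter). For compound 4 the estimated value is 5000 nM, within an expected range of 1200 nM to 30000 nM.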

Compound 4, half-maximal inhibitory concentration: > 10000 nM
Compound 4 gave a limit, no number (the forecaster's own chance of this, stated with the estimate: 30%); at least 2.0-fold (0.30 log units) between middle value and limit.
By their numbers in this assay, from the lowest: compounds 2 and 1 (each within the scatter of the next); then compound 3. At a limit, above all of these: compound 4.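

In this assay, compound 4 gave a limit rather than a number: > 10000 nM. Putting carboxy in place of methyl on this saturated chain carbon, two bonds along the chain from an aromatic nitrogen, gives an at least 4.7-fold higher number from compound 3 to compound 4 (0.67 log units; beyond the scatter), so this position responds to change and the change moves towards weaker inhibition. The true size of the step stays open, and only its lower bound is known: the limit of > 10000 nM in this assay, at which 1 of the 4 values shown sits.

The compounds shown leave open whether an amine, an amide or a longer chain ending in a carboxylic acid would behave like carboxy or like methyl here.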